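The source may report more compounds than this note shows. Statements on the series, on what has been measured and on what is new or still open speak of the compounds shown alone.

In a functional assay on the whole organism (plasma, strain Wistar) with Rattus norvegicus as the target, with a stated time of 15 days, at a dose of 3 mg/kg by the oral route (on this read-out lower numbers stand for a weaker effect and higher numbers for a stronger effect at the one dose given), compound 1 `Cc1nc(COc2ccc(/C=C3\SC(=O)NC3=O)cc2)cs1` gives 10.4%. Compound 2 `O=C1NC(=O)/C(=C/c2ccc(OCCSc3nnc(Cc4ccccc4)[nH]3)cc2)S1` gives 18.3% in this assay, the higher of the two numbers, though the gap to compound 1 lies within the usual scatter, so neither compound can be called the stronger on these data. Going by the values given here, the two compounds differ in more than one place, and no single step joins them. Compound 3 `O=C1NC(=O)/C(=C/c2ccc(OCCSc3nnc(-c4ccc([N+](=O)[O-])cc4)[nH]3)cc2)S1` differs from compound 2 in one place: 4-nitrophenyl in place of benzyl on an aromatic carbon. Among the compounds with values here, nothing among the measured compounds shows what this change does in this assay. The expected step of a number 0.3 percentage points lower from compound 2 to compound 3 (within the scatter) is therefore taken as none beyond the scatter, in neither direction. Compound 3 is expected to give about 18% in this assay, with a range from 5% to 35%.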

Compound 3, a percentage reported as activity, at one dose (the size of the read-out at that dose, not a potency): 11.9%
For compound 3 the middle estimate is 6.1 percentage points above the measured one; the range from low to high includes it.
By their numbers in this assay, from the lowest: compounds 1, 3 and 2 (each within the scatter of the next).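

At the aromatic carbon of the five-membered aromatic ring with 3 nitrogen, this assay now gives a first reading: 4-nitrophenyl in place of benzyl comes with a number 6.4 percentage points lower from compound 2 to compound 3 (within the scatter) for this pair. The exchange of benzyl for 4-nitrophenyl therefore has no effect here that can be told apart from the scatter, in either direction, and this position accepts either group without a clear difference on this read-out. Nothing at hand offers an explanation for this result.

Going by these compounds, whether an amine, a carboxylic acid or a longer chain on the same aromatic carbon would move the read-out beyond the scatter remains open. Going by these compounds alone, this single pair also cannot show whether the same exchange would read alike on a different core, and compound 1 differs from both in more than one place, so no step to it can be read.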